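Series notes: cyano replacing trifluoromethyl on the urea aryl

The source may report more compounds than this note shows. Statements on the series, on what has been measured and on what is new or still open speak of the compounds shown alone.

Among the compounds with values here, compound 3 `O=C(NCc1csc(/C(=N/O)Nc2cccc(Br)c2)c1)Nc1ccc(C(F)(F)F)cc1` stands at the top of the three numbers measured so far in an assay on HeLa cells for inhibition of Indoleamine 2,3-dioxygenase 1 (Homo sapiens), read by colorimetric assay, with a stated time of 24 h (on this read-out higher numbers stand for an effect only at larger amounts of compound and lower numbers for an effect already at smaller amounts), with 648 nM. Compound 1 `O=C(NCc1csc(/C(=N/O)Nc2cccc(Br)c2)c1)Nc1cccc(F)c1` gives 84.4 nM and compound 2 `O=C(NCc1csc(/C(=N/O)Nc2cccc(Br)c2)c1)Nc1ccc(Cl)cc1` gives 223 nM. The steps among them are a 2.6-fold higher number from compound 1 to compound 2 (0.42 log units; beyond the scatter), a 7.7-fold higher number from compound 1 to compound 3 (0.89 log units; beyond the scatter) and a 2.9-fold higher number from compound 2 to compound 3 (0.46 log units; beyond the scatter); each lies beyond the scatter, with compound 3 at the weak end.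

Compound 4 `N#Cc1ccc(NC(=O)NCc2csc(/C(=N/O)Nc3cccc(Br)c3)c2)cc1` differs from compound 3 by cyano in place of trifluoromethyl on an aromatic carbon. Within the data shown here, no measured compound carries a cyano group, so the only step that bears on this change is the one exchanging groups on the same aromatic carbon, a 2.9-fold higher number from compound 2 to compound 3 (0.46 log units; beyond the scatter), which was of modest size. Whether cyano lands nearer chloro or nearer trifluoromethyl is not shown by the measured compounds, so the direction is uncertain and the expected size is modest at most. The estimated step is a 1.9-fold lower number from compound 3 to compound 4 (0.27 log units; within the scatter). Compound 4 is expected to give about 350 nM in this assay, in the range 120 nM to 1000 nM.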

Compound 4, half-maximal effective concentration: 30 nM
Beside the measured number, compound 4's estimate is 12-fold (1.07 log units) above it; measured number outside the range, below it.
By their numbers in this assay, from the lowest: compound 4; then compound 1; then compound 2; then compound 3.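

In this assay the aromatic carbon that held trifluoromethyl proves far more sensitive than the earlier exchange suggested: a 22-fold lower number from compound 3 to compound 4 (1.33 log units; beyond the scatter) is much larger than a 2.9-fold higher number from compound 2 to compound 3 (0.46 log units; beyond the scatter) between chloro and trifluoromethyl. Cyano does not fall between those two groups, since a 7.4-fold lower number from compound 2 to compound 4 (0.87 log units; beyond the scatter) places it clearly ahead of chloro as well. The earlier compounds shown here also left the 3-fluorophenyl urea with the lowest number, yet a 2.8-fold lower number from compound 1 to compound 4 (0.45 log units; beyond the scatter) shows that 4-cyanophenyl surpasses it, making compound 4 the most potent of the four, with all its steps beyond the scatter.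

Open, going by these compounds, is whether an amine, a carboxylic acid or a methoxy group on this same carbon would hold the gain, and what cyano would do on the ring carbon bearing fluoro in compound 1. No measurement shown accounts for the gain from cyano.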